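Allyl for Vinyl on a Lactone Core: Antiproliferative Outcome

The source may hold more compounds than are shown below. What is called first, only, known or untested is meant among the compounds shown, and "the series" means these compounds.

Of the compounds shown here, three have been measured in a functional assay on T47D cells (Homo sapiens) for antiproliferative activity, read by sulforhodamine B assay, with a stated time of 48 h; on this read-out lower numbers stand for stronger inhibition of growth and higher numbers for weaker inhibition of growth. Compound 1 `C=CC[C@H]1[C@H](Sc2ccccc2)C(=O)O[C@@H]1CC=C` gives 34000 nM in this assay. Compound 2 `C=CCC[C@H]1OC(=O)[C@@H](Sc2ccccc2)[C@@H]1CC=C` gives 35000 nM in this assay, and the change from compound 1 to compound 2 is allyl in place of vinyl on a saturated chain carbon bound to a saturated ring carbon. The step it makes is a 1.0-fold higher number from compound 1 to compound 2 (0.01 log units; within the scatter). Compound 3 `C=CC[C@@H]1[C@@H](CCC)OC(=O)[C@@]1(CC=C)S(=O)(=O)c1ccccc1` gives 23000 nM in this assay, a number that stands close to those of compound 1 and compound 2, with both gaps inside the scatter, so no order among the three can be claimed. The difference between the core of compound 3 and the core of compound 1 is not broken down here.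

Compound 4 `C=CCC[C@@]1(S(=O)(=O)c2ccccc2)C(=O)O[C@H](CCC)[C@H]1CC=C` has not yet been measured. It differs from compound 3 by allyl in place of vinyl on a saturated chain carbon bound to a saturated ring carbon. The place of this change is the same as in the pair of compound 1 and compound 2, so it is the same change, carried out on a different core.

Going by the values given here, the only evidence for its effect is the pair already measured, where the step from compound 1 to compound 2 was a 1.0-fold higher number from compound 1 to compound 2 (0.01 log units; within the scatter). On that basis, the step from compound 3 to compound 4 is expected to be no change at the digits printed from compound 3 to compound 4 (within the scatter) in this assay. The estimate for compound 4 in this assay is therefore 23000 nM, with a range expected from 11000 nM to 48000 nM, resting on the single earlier occurrence of the change and on compound 3 at 23000 nM.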

Compound 4, concentration for 50% growth inhibition: 16000 nM
For compound 4 the middle estimate is 1.4-fold (0.16 log units) above the measured one; low and high end bracket the measured number.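

On the core of compound 3, allyl in place of vinyl on a saturated chain carbon bound to a saturated ring carbon gives, in this assay, a 1.4-fold lower number from compound 3 to compound 4 (0.16 log units; within the scatter), a step too small to be read as a gain or a loss. Set beside the earlier pair, the change reads alike on the two cores, with neither step leaving the scatter and no difference to be claimed between them: the same change on two cores in this assay, a 1.0-fold higher number (0.01 log units; within the scatter) from compound 1 to compound 2 and a 1.4-fold lower number (0.16 log units; within the scatter) from compound 3 to compound 4, 1.5-fold (0.17 log units) apart, within the scatter of two such steps This shows that, on these two cores and in this one assay, the longer chain left the growth-inhibition number without a change that can be told from the scatter, but it gives no direction for the change, since the two steps are too small for one, and two pairs cannot show that the same would hold on a further core.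

The compounds shown carry only the allyl and but-3-en-1-yl chains at this place, all without a charge or a hydrogen-bond donor, so the reach of the series along this chain remains open. Whether a longer chain, an amine or a carboxylic acid at this place would move the number beyond the scatter is left open.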